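The source may report more compounds than this note shows. Statements on the series, on what has been measured and on what is new or still open speak of the compounds shown alone.

Measured in an assay on cells for inhibition of MAP kinase-interacting serine/threonine-protein kinase 1 (Homo sapiens), read by mobility shift assay, with stated times of 10 min and 60 min, in the presence of a further agent that is not named here; a higher number here means a weaker inhibitor, a lower number a stronger inhibitor:
compound 1 `NC(=O)c1ccc(-c2cccnc2)cc1OC1CCC1` — 1900 nM
compound 2 `NC(=O)c1ccc(-c2cccnc2)cc1` — 8800 nM
compound 3 `CC(C)Oc1cc(-c2cncc(-c3c[nH]nc3C3CC3)c2)ccc1C(N)=O` — 130 nM

Compound 3 gives the lowest number of the three in this assay, well clear of both others. Within the data shown here, the only measured step, a 4.6-fold higher number from compound 1 to compound 2 (0.67 log units; beyond the scatter), concerns a different change and does not bear directly on the one considered next. Compound 4 `CC(C)Oc1cc(-c2cccnc2)ccc1C(N)=O` is derived from compound 3 by hydrogen in place of 3-cyclopropyl-1H-pyrazol-4-yl on an aromatic carbon. Compound 1, which also lacks the 3-cyclopropyl-1H-pyrazol-4-yl group, gives 1900 nM in this assay and is the closest point of comparison. Compound 4 is therefore expected to fall back toward that level, with an estimated step of a 15-fold higher number from compound 3 to compound 4 (1.19 log units; beyond the scatter) toward the weaker side. The estimate for compound 4 is 2000 nM, ranging from 700 nM to 6000 nM.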

Compound 4, half-maximal inhibitory concentration: 880 nM
For compound 4 the middle estimate is 2.3-fold (0.36 log units) above the measured one; the measured number falls inside the stated range.
By their numbers in this assay, from the lowest: compound 3; then compound 4; then compound 1; then compound 2.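

In this assay, hydrogen in place of 3-cyclopropyl-1H-pyrazol-4-yl gives a 6.8-fold higher number from compound 3 to compound 4 (0.83 log units; beyond the scatter) with the isopropoxy group held constant, so the group at this position carries part of the inhibition in compound 3. Without that group, isopropoxy in place of hydrogen gives a 10-fold lower number from compound 2 to compound 4 (1.00 log units; beyond the scatter) and isopropyl in place of cyclobutyl on the oxygen gives a 2.2-fold lower number from compound 1 to compound 4 (0.33 log units; beyond the scatter) as the smaller step.

Open, as far as these compounds go, is how an amine or a carboxylic acid would compare at this position with the 3-cyclopropyl-1H-pyrazol-4-yl group. No evidence on the origin of these steps is at hand.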